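This account rests on a few compounds, and the source may have more. Where it says the series, first, only, none or still open, it means among the compounds named here.

In an ADME assay on HEK293 cells (Homo sapiens) for cytotoxicity, read by MTT assay, with a stated time of 24 h (on this read-out lower numbers stand for stronger inhibition and higher numbers for weaker inhibition), compound 1 (`COC(=O)c1scc(-c2ccc(NC(=O)c3ccccn3)cc2)c1OC`) reads ("not determined" (no result reported)) and compound 2 (`COC(=O)c1scc(-c2ccc(NC(=O)c3ccc(F)c(Cl)n3)cc2)c1OC`) reads ("not determined" (no result reported)). Going by the values given here, compound 3 (`COC(=O)c1scc(-c2ccc(NC(=O)c3cc(I)ccc3F)cc2)c1OC`) gives 45300 nM as the only number, so it has no measured neighbour to be ranked against. Compound 4 (`COC(=O)c1scc(-c2ccc(NC(=O)c3ccc(OC)nc3)cc2)c1OC`) awaits measurement. It carries 6-methoxypyridin-3-yl in place of 2-fluoro-5-iodophenyl on a carbonyl carbon. Among the compounds with values here, no step between measured compounds is available to size this change, so the expectation rests on compound 3 at 45300 nM alone, and no shift beyond the usual scatter is expected in either direction. The estimated step is small (a 1.1-fold higher number from compound 3 to compound 4 (0.04 log units; within the scatter)). Compound 4 is expected at 50000 nM in this assay with an estimated range (18000 nM to 120000 nM).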

Compound 4, half-maximal inhibitory concentration: > 50000 nM
Compound 4: no number, only a limit (the forecaster's own chance of this, stated with the estimate: 20%); the middle value sits exactly at the limit.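

Going by these compounds alone, the exchange of 2-fluoro-5-iodophenyl for 6-methoxypyridin-3-yl on a carbonyl carbon gives the first step, an at least 1.1-fold higher number from compound 3 to compound 4 (0.04 log units; that floor lies within the scatter), in this assay. The reading of compound 4 is a limit and not a number: the limit of > 50000 nM in this assay, at which 1 of the 4 values shown sits. On this evidence, the two groups at this position cannot be told apart in this assay.

Going by these compounds, how far the true step lies from that floor stays open. Also open, on these data alone, is how an aminopyridine or a benzoic acid group would read at this position.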